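A few compounds are considered here, and "the series" means these few. Any claim that something is new, unique, unknown or untested is made for them only; others in the source may bear on it.

Compound 1, `CCOC(=O)C(=O)Nc1nc(-c2cccc(O)c2)cs1`, gives in a functional assay on the whole organism with Rattus norvegicus as the target (on this read-out higher numbers stand for an effect only at larger amounts of compound and lower numbers for an effect already at smaller amounts), only a limit, > 10 mg/kg.
Compound 2, `CCOC(=O)C(=O)Nc1nc(-c2cccc(OC)c2)cs1`, gives in this assay a value of about 20 mg/kg.
Compound 3, `CCOC(=O)C(=O)Nc1nc(-c2ccc(OC)cc2OC)cs1`, gives in this assay only a limit, > 30 mg/kg.

From compound 2 to compound 1 the change is hydrogen in place of methyl on an oxygen on an aromatic ring. The step that the limit leaves unreadable from compound 2 to compound 1 has no readable size because of the limit of > 10 mg/kg in this assay, at which 1 of the 3 values shown sits. How the core of compound 3 differs from the core of compound 2 is not broken down here. The position of compound 3 rests on a limit, because of the limit of > 30 mg/kg in this assay, at which 1 of the 3 values shown sits.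

Compound 4, `CCOC(=O)C(=O)Nc1nc(-c2ccc(OC)cc2O)cs1`, has not yet been measured. Among the compounds with values here, it differs from compound 3 by hydrogen in place of methyl on an oxygen on an aromatic ring, which is the same change as the one from compound 2 to compound 1, made at a place described in the same words. Because the limit of > 10 mg/kg in this assay, at which 1 of the 3 values shown sits, the earlier step of this kind gives no guide to its size, and the starting point of compound 3 is itself only a limit. In this assay the expected step is therefore a step that the limit leaves unreadable from compound 3 to compound 4, and is stated as an expectation only. Compound 4 is estimated to give in this assay a value near 40 mg/kg, expected to lie between 15 mg/kg and 100 mg/kg, with a real chance that the read-out is again a limit.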

Compound 4, dose for half-maximal effect: about 1 mg/kg
Beside the measured number, compound 4's estimate is 40-fold (1.60 log units) above it; the whole stated range lies above it.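

In this assay, the change of methoxy to hydroxy on an aromatic ring gives an at least 30-fold lower number from compound 3 to compound 4 (1.47 log units; beyond the scatter), so on this core a single change is enough to bring the read-out down sharply. The true size of this step cannot be read beyond that bound, because its starting point is a limit for compound 3 and not a number: the limit of > 30 mg/kg in this assay, at which 1 of the 4 values shown sits. The result does not show that the change carries from one core to another, because the same change on the core of compound 2 gives a step that cannot be read, as compound 1 stands only at a limit: the limit of > 10 mg/kg in this assay, at which 1 of the 4 values shown sits.

The compounds shown leave open whether the drop depends on the second methoxy group that compound 4 keeps on its ring, or would appear with the hydroxy group alone at that place. They also leave open how an amine in place of the hydroxy group, or a carboxylic acid in place of the ethyl ester, would read in this assay.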